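This account rests on a few compounds, and the source may have more. Where it says the series, first, only, none or still open, it means among the compounds named here.

Measured so far in a functional assay on MGC-803 cells (Homo sapiens) for cytotoxicity, read by MTT assay, with a stated time of 48 h; on this read-out lower numbers stand for stronger inhibition and higher numbers for weaker inhibition

Compound 1 `CC1=NN(C(=O)COc2ccc(Cl)cc2)C(c2ccccc2O)C1` gives "not active" (no number reported)
Compound 2 `CCN(CC)CC(=O)N1N=C(C)CC1c1ccccc1O` gives 39800 nM
Compound 3 `CC1=NN(C(=O)CN2CCCC2)C(c2ccccc2O)C1` gives 17900 nM

Of the two numbers, compound 3 holds the lower one (17900 nM). Compound 1 gave no number and cannot be ranked with the other two.

Compound 4 `CC1=NN(C(=O)CN2CCC(Cl)CC2)C(c2ccccc2O)C1` has not yet been measured. It departs from compound 3 on a saturated chain carbon bound to a carbonyl carbon, and the change is 4-chloropiperidin-1-yl in place of pyrrolidin-1-yl on a saturated chain carbon bound to a carbonyl carbon in full. Within the data shown here, only one measured step bears on this place, a 2.2-fold lower number from compound 2 to compound 3 (0.35 log units; beyond the scatter) for pyrrolidin-1-yl in place of diethylamino. Among the measured compounds shown here, that step is modest and is the only guide to how far a change here moves the number. For the measured compounds named here, no measured compound carries 4-chloropiperidin-1-yl, so the data give no direction for the group that enters. The step expected in this assay is therefore small, most likely no larger than the modest one already seen and probably within the scatter, with no firm direction. The estimated step is a 1.1-fold lower number from compound 3 to compound 4 (0.05 log units; within the scatter) and remains an expectation until the measurement is made. Compound 4 is expected at 16000 nM (estimated range 5500 nM to 45000 nM).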

Compound 4, half-maximal inhibitory concentration: 30300 nM
Beside the measured number, compound 4's estimate is 1.9-fold (0.28 log units) below it; low and high end bracket the measured number.
By their numbers in this assay, from the lowest: compounds 3, 4 and 2 (each within the scatter of the next, the first and the last beyond it).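

In this assay, among these compounds, 4-chloropiperidin-1-yl gives the first reading for a six-membered ring carrying chlorine on a saturated chain carbon bound to a carbonyl carbon, and the result is a 1.7-fold higher number from compound 3 to compound 4 (0.23 log units; within the scatter) and a 1.3-fold lower number from compound 2 to compound 4 (0.12 log units; within the scatter). Compound 4 therefore cannot be told apart from either compound 2 or compound 3, although those two are separated by a 2.2-fold lower number from compound 2 to compound 3 (0.35 log units; beyond the scatter), so this exchange of rings moves the number no further than repeat measurements would. No measurement at hand offers an explanation for this result.

As far as these compounds go, whether a plain piperidin-1-yl would read differently from compound 4, and so whether the chlorine matters at all in this assay, stays open. From the compounds shown here alone, it is also open whether a morpholin-4-yl, a primary amine or a longer chain at this place would move the number beyond the scatter by more than the modest step seen so far.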